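A few compounds are considered here, and "the series" means these few. Any claim that something is new, unique, unknown or untested is made for them only; others in the source may bear on it.

Compound 1, `Cc1ccc(NC(=O)[C@H]2CN(C)C[C@@H]2c2ccc(/C=C/C(=O)Nc3ccccc3N)cc2)cc1`, in an in vitro ADME assay on microsomes from liver (Homo sapiens) for pharmacokinetics, read by LC-MS, with a stated time of 10 min, tested at 1 uM (a higher number here means faster removal of the compound, a lower number slower removal), gives 15 mL/min/kg.
Compound 2, `CN1C[C@H](C(=O)Nc2ccc(C3CC3)cc2)[C@@H](c2ccc(/C=C/C(=O)Nc3ccccc3N)cc2)C1`, in this assay gives 12 mL/min/kg.

Compound 2 holds the lower of the two numbers, though the gap to compound 1 is within the scatter. Compound 3, `CN1C[C@H](C(=O)Nc2cccc(F)c2)[C@@H](c2ccc(/C=C/C(=O)Nc3ccccc3N)cc2)C1`, differs from compound 2 by 3-fluorophenyl in place of 4-cyclopropylphenyl on an amide-type nitrogen. Going by the values given here, the one measured step, a 1.3-fold lower number from compound 1 to compound 2 (0.10 log units; within the scatter), also swapped a group on that same amide-type nitrogen and stayed within the scatter, so for compound 3 no step beyond the scatter is expected in this assay. Compound 3 is therefore estimated at 13 mL/min/kg, with a range of 7 mL/min/kg to 26 mL/min/kg. The expected step, a 1.1-fold higher number from compound 2 to compound 3 (0.03 log units; within the scatter), is expected to lie within the scatter.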

Compound 3, clearance: 6 mL/min/kg
Estimate against measurement, compound 3: 2.2-fold (0.34 log units) above; the whole stated range lies above it.
By their numbers in this assay, from the lowest: compounds 3, 2 and 1 (each within the scatter of the next, the first and the last beyond it).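

In this assay, going by these compounds alone, 3-fluorophenyl on the amide-type nitrogen gives a 2.5-fold lower number from compound 1 to compound 3 (0.40 log units; beyond the scatter), the first step at this position to pass the scatter, though only modestly, while the change from 4-cyclopropylphenyl gives a 2.0-fold lower number from compound 2 to compound 3 (0.30 log units; within the scatter). The group on this nitrogen can therefore move the number, which the step between the two earlier compounds did not show. Nothing available explains this shift. The compounds shown leave open whether 4-fluorophenyl would read like 3-fluorophenyl. They also leave open how an unsubstituted phenyl, a pyridyl or a phenyl bearing an amine would read at this nitrogen.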